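A few compounds are considered here, and "the series" means these few. Any claim that something is new, unique, unknown or untested is made for them only; others in the source may bear on it.

Measured compounds in a functional assay on SK-BR-3 cells (Homo sapiens) for antiproliferative activity, read by MTT assay, with a stated time of 72 h; on this read-out lower numbers stand for stronger inhibition and higher numbers for weaker inhibition:
compound 1 `CCN1CCN(c2cc(C)c3cc(NC(=O)c4ccccc4C)ccc3n2)CC1` gives 29200 nM
compound 2 `CCN1CCN(c2cc(C)c3cc(NC(=O)c4ccccc4F)ccc3n2)CC1` gives 38100 nM
compound 3 `CCN1CCN(c2cc(C)c3cc(NC(=O)c4ccccc4Cl)ccc3n2)CC1` gives only a limit of the assay, > 50000 nM

Compound 2 holds the highest of the two numbers; nearest is compound 1, and the step of a 1.3-fold higher number from compound 1 to compound 2 (0.12 log units; within the scatter) is within the scatter. Compound 3 sits at the limit of > 50000 nM in this assay, at which 1 of the 3 values shown sits. The other steps, an at least 1.7-fold higher number from compound 1 to compound 3 (0.23 log units; that floor lies within the scatter) and an at least 1.3-fold higher number from compound 2 to compound 3 (0.11 log units; that floor lies within the scatter), have floors that are also within the scatter, so the three measured compounds are not separated by this assay.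

Compound 4 `CCN1CCN(c2cc(C)c3cc(NC(=O)c4ccc(Cl)c(Cl)c4)ccc3n2)CC1` differs from compound 2 by 3,4-dichlorophenyl in place of 2-fluorophenyl on a carbonyl carbon. The measured steps each exchange a single group on the phenyl ring and none moved the number beyond the scatter; the change to compound 4 is larger than any of them, so they bear on it only loosely. The expectation is no step beyond the scatter, a 1.1-fold higher number from compound 2 to compound 4 (0.04 log units; within the scatter), with a real chance that compound 4 also returns only a limit. Compound 4 is estimated at 42000 nM, within 15000 nM to 120000 nM.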

Compound 4, half-maximal inhibitory concentration: 2160 nM
Compound 4: middle estimate off by 19-fold (1.29 log units), on the high side; measured number below the stated range.
By their numbers in this assay, from the lowest: compound 4; then compounds 1 and 2 (each within the scatter of the next). At a limit, above all of these: compound 3.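

Within the data shown here, with 3,4-dichlorophenyl on a carbonyl carbon, the series gives its first steps beyond the scatter in this assay, namely an 18-fold lower number from compound 2 to compound 4 (1.25 log units; beyond the scatter) and a 14-fold lower number from compound 1 to compound 4 (1.13 log units; beyond the scatter) and so this place can move the number, which the exchanges among the earlier compounds did not show. The step of an at least 23-fold lower number from compound 3 to compound 4 (1.36 log units; beyond the scatter) is also large, but it is only a floor. Compound 3 gives a limit and not a number: the limit of > 50000 nM in this assay, at which 1 of the 4 values shown sits.

From the compounds shown here alone, what stays open is whether a single chloro group placed as in 3,4-dichlorophenyl would carry the step, or whether both chloro groups are needed. Also open, going by these compounds, is how an amine or a carboxylic acid on that phenyl ring would read in this assay.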